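From compound 1 to compound 3: one group exchanged

The source may report more compounds than this note shows. Statements on the series, on what has been measured and on what is new or still open speak of the compounds shown alone.

Measured in a functional assay on A549 cells (Homo sapiens) for cytotoxicity, read by MTT assay, with a stated time of 72 h; on this read-out higher numbers stand for weaker inhibition and lower numbers for stronger inhibition:
- compound 1 `O=C(N/N=C/c1ccc(F)cc1Cl)Nc1cc2c(Nc3ccc(F)c(Cl)c3)ncnc2cc1O[C@H]1CCOC1`: 27200 nM
- compound 2 `O=C(N/N=C/c1cc(Br)c(O)c(Br)c1)Nc1cc2c(Nc3ccc(F)c(Cl)c3)ncnc2cc1O[C@H]1CCOC1`: 8910 nM

For the measured compounds named here, of the two numbers so far, compound 1 holds the higher, at 27200 nM, and so shows the weaker inhibition. Compound 3 `O=C(N/N=C/c1ccc(O)cc1O)Nc1cc2c(Nc3ccc(F)c(Cl)c3)ncnc2cc1O[C@H]1CCOC1` has not yet been measured. It keeps the core of compound 1 and changes one group: 2,4-dihydroxyphenyl in place of 2-chloro-4-fluorophenyl on a carbon with a double bond to nitrogen. Going by the values given here, the exchange falls on a carbon with a double bond to nitrogen, the same place that differs in the only measured step. There, 3,5-dibromo-4-hydroxyphenyl in place of 2-chloro-4-fluorophenyl gave a 3.1-fold lower number from compound 1 to compound 2 (0.48 log units; beyond the scatter), a modest change. Among the compounds with values here, compound 2, at 8910 nM, is thus the only guide, and it carries a different group from compound 3. A step of similar size towards a lower number is therefore expected in this assay, though a single step supports this only loosely. The expected change is a 2.3-fold lower number from compound 1 to compound 3 (0.36 log units; beyond the scatter). For compound 3 the estimated value is 12000 nM, with an expected range of 4000 nM to 35000 nM.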

Compound 3, half-maximal inhibitory concentration: 9360 nM
Estimate against measurement, compound 3: 1.3-fold (0.11 log units) above, and the stated range covers the measured number.
By their numbers in this assay, from the lowest: compounds 2 and 3 (each within the scatter of the next); then compound 1.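

In this assay, a second replacement on a carbon with a double bond to nitrogen also moves the number beyond the scatter, a 2.9-fold lower number from compound 1 to compound 3 (0.46 log units; beyond the scatter), so a lower number has now followed the loss of 2-chloro-4-fluorophenyl with two different entering groups. Those two groups are not separated by this read-out, a 1.1-fold higher number from compound 2 to compound 3 (0.02 log units; within the scatter), which shows that the level of compound 2 is matched here by 2,4-dihydroxyphenyl, a group with no bromine, and that both compounds with a hydroxyl-bearing phenyl ring lie beyond the scatter from compound 1, which has neither hydroxyl group. Nothing available explains why these exchanges lower the number or why the two entering groups read alike.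

The three compounds do not separate the effect of adding hydroxyl groups from that of removing chlorine and fluorine, as both exchanges do the two together. On these data alone, it also remains open whether a methoxy group or an amine on the phenyl ring in place of hydroxyl would keep the number of compound 3, or whether a phenyl ring bearing only hydroxyl and the chlorine would do so.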